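This account rests on a few compounds, and the source may have more. Where it says the series, first, only, none or still open, it means among the compounds named here.

Measured compounds:
Compound 1, `CCCC[S@@+]([O-])CCCCN=C=S`, gives 17400 nM in an ADME assay on MRC5 cells (Homo sapiens) for cytotoxicity, read by MTT assay, with a stated time of 48 h; on this read-out higher numbers stand for weaker inhibition and lower numbers for stronger inhibition.
Compound 2, `C[S@@+]([O-])CCCCCN=C=S`, gives 18500 nM in this assay.

Compound 1 stands alongside compound 2 on these two numbers; the values of compound 1 and compound 2 lie within the usual scatter of each other, so no order between them can be claimed. Compound 2 carries a methyl on the sulfur where compound 1 carries a butyl, and the two values are nonetheless indistinguishable. The unmeasured compound 3, `CC[S@@+]([O-])CCCCN=C=S`, differs from compound 1 by hydrogen in place of ethyl on a saturated chain carbon, two bonds along the chain from a sulfur. Since compound 1 and compound 2 show that a shorter chain on the sulfur leaves the number unchanged within scatter, the step in this assay from compound 1 to compound 3 is expected to be none beyond the scatter, and the expected step is a 1.0-fold higher number from compound 1 to compound 3 (0.01 log units; within the scatter). Compound 3 is estimated at 18000 nM, with a range from 9000 nM to 36000 nM.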

Compound 3, half-maximal inhibitory concentration: 40800 nM
Compound 3: middle estimate off by 2.3-fold (0.36 log units), on the low side; measured number above the stated range.
By their numbers in this assay, from the lowest: compounds 1 and 2 (each within the scatter of the next); then compound 3.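

Cutting the butyl on the sulfur back to an ethyl, with the rest of the compound unchanged, gives a 2.3-fold higher number from compound 1 to compound 3 (0.37 log units; beyond the scatter) in this assay, a modest weakening of inhibition on this read-out. This is the first comparison shown that changes only this chain, and it shows that the number does respond to the chain's length at this position. The earlier pair differed in more than one place, so its closeness could not speak for this change alone. Nothing given here accounts for the step.

The compounds shown leave open whether the number climbs gradually or jumps as this chain shortens, which a propyl on the sulfur would help to settle. They also leave open whether a longer chain, such as hexyl, would bring the number down further.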